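Fluoro in place of bromo: from compound 3 to compound 4

The source may hold more compounds than are shown below. What is called first, only, known or untested is meant among the compounds shown, and "the series" means these compounds.

The three measured compounds were tested in a functional assay on SGC-7901 cells (Homo sapiens) for antiproliferative activity, read by MTT assay, with a stated time of 72 h; a lower number here means a stronger inhibitor, a higher number a weaker inhibitor:

compound 1 `C#Cc1cccc(Nc2ncnc3c(OC)c(OC)c(OC)cc23)c1` gives 5820 nM
compound 2 `COc1cc2c(Nc3ccc(Cl)cc3F)ncnc2c(OC)c1OC` gives > 30000 nM, a limit of the assay
compound 3 `COc1cc2c(Nc3cccc(Br)c3F)ncnc2c(OC)c1OC` gives > 30000 nM, a limit of the assay

Compound 3 stands at the limit (the limit of > 30000 nM in this assay, at which 2 of the 3 values shown sit), so only a bound is known for it, and the same holds for compound 2. Going by the values given here, compound 1 is the only compound with a number. The steps that involve the limit read as an at least 5.1-fold higher number from compound 1 to compound 2 (0.71 log units; beyond the scatter) and an at least 5.1-fold higher number from compound 1 to compound 3 (0.71 log units; beyond the scatter), while the step that the two limits leave unreadable from compound 2 to compound 3 cannot be read at all.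

Compound 4 `COc1cc2c(Nc3cccc(F)c3F)ncnc2c(OC)c1OC` differs from compound 3 by fluoro in place of bromo on an aromatic carbon. Among the compounds with values here, none of the measured steps isolates this halogen swap; the only readable information is that both compounds carrying a fluoro group in the same position as compound 4 sit at the limit. Compound 4 is therefore expected to remain at or near that limit, with an estimated step of a number no higher from compound 3 to compound 4 (the limit leaves the size open). For compound 4 the estimate in this assay is 30000 nM, within a range of 8000 nM to 100000 nM.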

Compound 4, half-maximal inhibitory concentration: > 30000 nM
Compound 4 ended at the assay's limit; the forecaster's own chance of this, stated with the estimate: 70%; the middle value sits exactly at the limit.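

In this assay compound 4 gives > 30000 nM, which is a limit of the assay and not a number. Swapping bromo for fluoro on this aromatic carbon, ortho to a fluoro group, therefore brings no measurable activity, and the steps among compound 2, compound 3 and compound 4 cannot be read. The one readable step is an at least 5.1-fold higher number from compound 1 to compound 4 (0.71 log units; beyond the scatter), so the 2,3-difluorophenyl group joins the other two halogenated groups on the far side of the 3-ethynylphenyl group of compound 1, and the shared ceiling now covers most of the series: the limit of > 30000 nM in this assay, at which 3 of the 4 values shown sit.

On these data alone, how far compound 2, compound 3 and compound 4 lie beyond that limit stays open. Also open, as far as these compounds go, is whether a different group on this carbon, such as an amine or a nitrile, or an ethynyl group alongside the fluoro group, would give a number in this assay.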